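The source may report more compounds than this note shows. Statements on the series, on what has been measured and on what is new or still open speak of the compounds shown alone.

Compound 1 `COc1ccc(Cl)cc1-n1ncc(-c2nnc(-c3ccc(C)c([N+](=O)[O-])c3)o2)c1C`: 6.42 in a physicochemical assay for lipophilicity, using the shake flask method, measured as octanol-water partition; on this read-out higher numbers stand for higher lipophilicity and lower numbers for lower lipophilicity
Compound 2 `COc1ccc(Cl)cc1-n1ncc(-c2nnc(-c3ccc(Br)c(C)c3)o2)c1C`: 5.2
Compound 3 `COc1ccc(Cl)cc1-n1ncc(-c2nnc(-c3ccc(Br)cc3)o2)c1C`: 4.88

Compound 2 stands second highest of the three numbers in this assay. Its nearest neighbour is compound 3, reached by the step of a number 0.32 log units lower from compound 2 to compound 3 (beyond the scatter), and its furthest is compound 1, from which the step of a number 1.22 log units lower from compound 1 to compound 2 (beyond the scatter) leads down to it. Compound 4 `COc1ccc(Cl)cc1-n1ncc(-c2nnc(-c3ccc(C)c(Br)c3)o2)c1C` differs from compound 2 in one place: 3-bromo-4-methylphenyl in place of 4-bromo-3-methylphenyl on an aromatic carbon. Among the compounds with values here, no measured step swaps two groups in this way. The closest measured step is the one that removes the methyl, a number 0.32 log units lower from compound 2 to compound 3 (beyond the scatter), which is modest. The two large steps, a number 1.22 log units lower from compound 1 to compound 2 (beyond the scatter) and a number 1.54 log units lower from compound 1 to compound 3 (beyond the scatter), replace the entire 4-methyl-3-nitrophenyl group and so bear on this change only loosely. As compound 2 and compound 4 hold the same atoms, the step in this assay is expected to lie within the scatter in either direction. Compound 4 is therefore estimated at 5.2, in the range 4.8 to 5.6. The expected step is no change at the digits printed from compound 2 to compound 4 (within the scatter), which is an estimate and not a measurement.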

Compound 4, partition coefficient: 5.19
Beside the measured number, compound 4's estimate is 0.01 log units above it; low and high end bracket the measured number.
By their numbers in this assay, from the lowest: compound 3; then compounds 4 and 2 (each within the scatter of the next); then compound 1.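

In this assay the exchange of 4-bromo-3-methylphenyl for 3-bromo-4-methylphenyl gives a number 0.01 log units lower from compound 2 to compound 4 (within the scatter) and so separates the two arrangements by nothing this read-out can resolve, at least on this aromatic carbon of the shared core. Placing 3-bromo-4-methylphenyl where 4-bromophenyl stood gives a number 0.31 log units higher from compound 3 to compound 4 (beyond the scatter) and shows that the modest step seen with 4-bromo-3-methylphenyl also appears with its isomer. Bromo in place of nitro, now a change in one place with the methyl kept, gives a number 1.23 log units lower from compound 1 to compound 4 (beyond the scatter) and is large, so most of the distance earlier seen only across whole-group replacements appears with this single exchange.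

The compounds shown leave open whether a group such as an amine or a carboxylic acid in place of the bromo would follow the same pattern. No measured evidence is at hand to account for any of these steps.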